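The source may report more compounds than this note shows. Statements on the series, on what has been measured and on what is new or still open speak of the compounds shown alone.

Compound 1 `CC1=C(C(=O)NC(C)C)C(c2ccco2)NC(=O)N1` gives 4% in an assay on membranes from HeLa cells for displacement of a labelled ligand from adenosine receptor A3 (Homo sapiens), read by scintillation counting, with a stated time of 180 min, tested at 1 uM; a higher number here means more inhibition at the concentration tested (going by the name of the read-out), a lower number less inhibition.
Compound 2 `CCN(CC)C(=O)C1=C(C)NC(=O)NC1c1ccco1` gives 19% in this assay.
Compound 3 `CC1=C(C(=O)NC(C)C)C(c2ccoc2)NC(=O)N1` gives 3% in this assay.

Compound 4 `CCN(CC)C(=O)C1=C(C)NC(=O)NC1c1ccoc1` has not yet been measured in this assay.

Compound 2 differs from compound 1 in one place: diethylamino in place of isopropylamino on a carbonyl carbon. This change gave a number 15 percentage points higher from compound 1 to compound 2 (beyond the scatter). Compound 3 has a different core from compound 1: furan-3-yl in place of furan-2-yl on a saturated ring carbon. That swap gave a number 1 percentage points lower from compound 1 to compound 3 (within the scatter), so the two cores behave alike in this assay as far as these two compounds show.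

Compound 4 stands to compound 3 as compound 2 stands to compound 1: diethylamino in place of isopropylamino on a carbonyl carbon. The surroundings of the place are the same in both pairs, so this is the same change, now made on the core of compound 3. Because the earlier instance gave a number 15 percentage points higher from compound 1 to compound 2 (beyond the scatter), the same change is expected to give a step of similar size here, a number 14 percentage points higher from compound 3 to compound 4 (beyond the scatter). For the measured compounds named here, only one earlier instance exists, so this expectation rests on a single pair of measurements. Compound 4 is therefore estimated at 17%, with 5% to 30% as its likely range in this assay.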

Compound 4, a percentage reported as inhibition, at one concentration (the size of the read-out at that concentration, not a potency): 37%
For compound 4 the middle estimate is 20 percentage points below the measured one; the whole stated range lies below it.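

On the core of compound 3, diethylamino in place of isopropylamino gave a number 34 percentage points higher from compound 3 to compound 4 (beyond the scatter), so the direction carried over from the earlier pair but the size did not: the same change on two cores in this assay, a number 15 percentage points higher (beyond the scatter) from compound 1 to compound 2 and a number 34 percentage points higher (beyond the scatter) from compound 3 to compound 4, 19 percentage points apart, beyond the scatter of two such steps

The same four compounds can be read the other way: furan-3-yl in place of furan-2-yl made no clear difference with isopropylamino on the carbonyl carbon, yet with diethylamino there it gave a number 18 percentage points higher from compound 2 to compound 4 (beyond the scatter): the same change on two cores in this assay, a number 1 percentage points lower (within the scatter) from compound 1 to compound 3 and a number 18 percentage points higher (beyond the scatter) from compound 2 to compound 4, 19 percentage points apart, beyond the scatter of two such steps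

So in this assay the effects of the two changes do not simply add up, but this rests on a single set of four compounds and shows neither why the step grew nor whether the same would happen on any other core.

On these data alone, it remains open whether a ring amine such as piperidine, or a longer chain such as dipropylamino, on the carbonyl carbon would raise the number further. As far as these compounds go, it is also open whether a thiophene in place of the furan would depend on the amide in the same way.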